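Replacing pyridin-3-yl with thiophen-3-yl on compound 1

The source may hold more compounds than are shown below. What is called first, only, known or untested is meant among the compounds shown, and "the series" means these compounds.

Among the measured compounds shown here, in a functional assay on HCT-116 cells (Homo sapiens) for antiproliferative activity, read by CellTiter-Glo, with a stated time of 72 h (on this read-out lower numbers stand for stronger inhibition and higher numbers for weaker inhibition), compound 1 `O=C(NO)c1ccc(/C=C/c2ccnc(-c3cccnc3)c2)cc1` gives 5140 nM, the only actual number among the three compounds measured so far. Compound 2 `O=C(NO)c1ccc(/C=C/c2cccc(-c3cccc(O)c3)c2)cc1` reads > 10000 nM, which is a limit of the assay. Compound 3 `O=C(NO)c1ccc(/C=C/c2cc(-c3ccc(C(F)(F)F)cc3)ncc2F)cc1` reads > 10000 nM, which is also a limit.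

Compound 4 `O=C(NO)c1ccc(/C=C/c2ccnc(-c3ccsc3)c2)cc1` keeps the core of compound 1 and carries thiophen-3-yl in place of pyridin-3-yl on an aromatic carbon. For the measured compounds named here, no measured pair of compounds isolates a change of this kind, so the data offer no direct guide to its size. Going by the values given here, the only anchor is compound 1 at 5140 nM, and the expectation stays close to it. In this assay, no step beyond the scatter is expected in either direction. The estimated change is a 1.1-fold lower number from compound 1 to compound 4 (0.06 log units; within the scatter). Compound 4 is expected to give about 4500 nM. The estimated range for compound 4 runs from 1500 nM to 10000 nM.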

Compound 4, half-maximal inhibitory concentration: 1910 nM
For compound 4 the middle estimate is 2.4-fold (0.37 log units) above the measured one; low and high end bracket the measured number.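

In this assay, among the compounds shown here, placing thiophen-3-yl instead of pyridin-3-yl on the aromatic carbon next to the ring nitrogen gives a 2.7-fold lower number from compound 1 to compound 4 (0.43 log units; beyond the scatter), the first step in this set that can be read. It shows that this position accepts a five-membered aromatic ring in place of a six-membered one, and that this exchange moves the number in the direction of stronger inhibition, though only modestly. Compound 2 and compound 3 differ from compound 1 in more than one place and offer no such comparison.

Whether ring size or the sulfur atom accounts for the step stays open, as does the effect of a furan-3-yl ring here or of an amine or a carboxylic acid on the thiophen-3-yl ring. A change toward weaker inhibition at this position might not be sized at all, as the assay has a limit: the limit of > 10000 nM in this assay, at which 2 of the 4 values shown sit.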